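The source may hold more compounds than are shown below. What is called first, only, known or untested is meant among the compounds shown, and "the series" means these compounds.

Compound 1 `CC(C)(C)OC(=O)N1CCC(O[C@H]2CC[C@H](Oc3ccc(S(C)(=O)=O)cc3F)CC2)CC1` gives 119%
Compound 2 `CS(=O)(=O)c1cnc(O[C@H]2CC[C@H](OC3CCN(C(=O)Oc4ccccc4)CC3)CC2)cn1` gives 104%
Compound 3 `CS(=O)(=O)c1cnc(O[C@H]2CC[C@H](OC3CCN(C(=O)C4(C(F)(F)F)CCCC4)CC3)CC2)cn1` gives 124%

In a functional assay on isolated protein for agonist activity at Glucose-dependent insulinotropic receptor (Rattus norvegicus), read by HTRF and cAMP accumulation (a higher number here means a larger maximal response, a lower number a smaller maximal response), compound 3 gives 124%, the highest of the three numbers. Compound 1 lies within the scatter of it, so no order between the two can be claimed. Among the measured compounds shown here, compound 2 lies beyond the scatter below it: the only single change measured here is a number 20 percentage points higher from compound 2 to compound 3 (beyond the scatter), where a group on the carbonyl carbon was swapped.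

Compound 4 `CC(F)Cc1nc(CN2CCC(O[C@H]3CC[C@H](Oc4cnc(S(C)(=O)=O)cn4)CC3)CC2)no1` is the next compound. It differs from compound 3 in this way: a group of 10 heavy atoms (6 carbon, 2 nitrogen, 1 oxygen, 1 fluorine; one five-membered aromatic ring with 3 hetero atoms) in place of a group of 11 heavy atoms (7 carbon, 1 oxygen, 3 fluorine; one five-membered non-aromatic ring of carbon only), on an amine nitrogen in a ring. This change sits on the amine nitrogen in the ring, not on a carbonyl carbon, so the measured step from compound 2 to compound 3 bears on it only loosely; it shows that swapping the group at that end of the molecule moves the maximal response by a modest amount. With three compounds spanning a narrow band, the expectation for compound 4 is a small move downward or none beyond the scatter, estimated as a number 16 percentage points lower from compound 3 to compound 4 (beyond the scatter), giving 108% with a range from 88% to 128%.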

Compound 4, largest response reached (Emax), in percent of the reference or control that the assay uses: 114%
Compound 4: the middle estimate sits 6 percentage points below what was measured; measured number inside the range.
By their numbers in this assay, from the lowest: compounds 2, 4, 1 and 3 (each within the scatter of the next, the first and the last beyond it).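

In this assay, replacing the group on the amine nitrogen with (5-(2-fluoropropyl)-1,2,4-oxadiazol-3-yl)methyl gives a number 10 percentage points lower from compound 3 to compound 4 (within the scatter) and also a number 10 percentage points higher from compound 2 to compound 4 (within the scatter). The earlier compounds shown here all carry a carbonyl on this nitrogen, whereas compound 4 shows that a large maximal response is also reached with an aromatic ring of three hetero atoms, joined through a methyl carbon. Compound 4 lies within the scatter of both compounds, so it cannot be ranked against either, and no measurement at hand explains the result.

Going by these compounds, it remains open whether a plain propyl chain in place of 2-fluoropropyl would give a similar maximal response. A carboxylic acid on this chain is also untested among the compounds shown, and maximal response alone does not tell how much compound is needed to reach it.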